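Aryl ether series: cytotoxicity in PBMC, trifluoromethyl removal

This account rests on a few compounds, and the source may have more. Where it says the series, first, only, none or still open, it means among the compounds named here.

Measured so far:
compound 1 `CC(CCNC(=O)c1c(Cl)cncc1Cl)N1CCC(C(Oc2cccc(C(F)(F)F)c2)c2ccc(C(F)(F)F)cc2)CC1` — 7000 nM
compound 2 `CCO/N=C(/c1ccc(Br)cc1)C1CCN(C(C)CNC(=O)c2c(C)cc[n+]([O-])c2C)CC1` — 182000 nM
compound 3 `CC(CCNC(=O)c1c(Cl)cncc1Cl)N1CCC(C(Oc2cccc(Cl)n2)c2ccc(S(C)(=O)=O)cc2)CC1` — > 29500 nM

Notes on the set. In an ADME assay on PBMC cells (Homo sapiens) for cytotoxicity (on this read-out lower numbers stand for higher toxicity in this test and higher numbers for lower toxicity in this test), compound 1 gives 7000 nM, the lowest of the two numbers recorded. Compound 2 gives 182000 nM in this assay, a higher number than compound 1 and beyond the scatter. For compound 3 this assay reports a limit, (the limit of > 29500 nM in this assay, at which 1 of the 3 values shown sits), and not a number.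

Compound 4 `CC(CCNC(=O)c1c(Cl)cncc1Cl)N1CCC(C(Oc2ccccc2)c2ccc(C(F)(F)F)cc2)CC1` is not yet measured. It differs from compound 1 in one place: hydrogen in place of trifluoromethyl on an aromatic carbon. Within the data shown here, no measured pair in this set carries this same change, so the direction is not fixed by data here. The expected step from compound 1 to compound 4 in this assay is a modest move towards a higher number, a 1.7-fold higher number from compound 1 to compound 4 (0.23 log units; within the scatter), with the possibility that the step stays within the scatter. Compound 4 is therefore estimated at 12000 nM in this assay, with a range of 5000 nM to 30000 nM, and a limit rather than a number cannot be ruled out.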

Compound 4, half-maximal cytotoxic concentration: 6800 nM
Estimate against measurement, compound 4: 1.8-fold (0.25 log units) above, and the stated range covers the measured number.
By their numbers in this assay, from the lowest: compounds 4 and 1 (each within the scatter of the next); then compound 2.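

Working from 3-(trifluoromethyl)phenoxy to phenoxy gives the first read on this position in this assay: a 1.0-fold lower number from compound 1 to compound 4 (0.01 log units; within the scatter). In this pair, the number recorded for compound 1 does not depend on the trifluoromethyl at this place; compound 4 keeps the second trifluoromethyl, so the pair says nothing about that group. Nothing on hand gives a cause for this result.

Still open, as far as these compounds go, is how this assay responds to other groups at this place, such as a methoxy group, an amine or a carboxylic acid. Also open, from the compounds shown here alone, is whether hydrogen in place of trifluoromethyl reads the same at the second trifluoromethyl or on a different core.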